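Removing the methyl from the methoxy group of compound 3

A few compounds are considered here, and "the series" means these few. Any claim that something is new, unique, unknown or untested is made for them only; others in the source may bear on it.

Within the data shown here, compound 3 `COc1cc(-c2nn(-c3cccc(NC(=O)Nc4ccc(Cl)c(C(F)(F)F)c4)c3)cc2-c2ccncc2)ccc1Cl` is the only member of this small set with a numerical reading in a functional assay on SW-620 cells (Homo sapiens) for inhibition, read by sulforhodamine B assay, with a stated time of 48 h; a higher number here means a weaker inhibitor of growth, a lower number a stronger inhibitor of growth: compound 3 gives 29900 nM. Compound 1 `O=C(Nc1cccc(-n2cc(-c3ccncc3)c(-c3ccc(Cl)c(O)c3)n2)c1)Nc1cccc(C(F)(F)F)c1` reaches only the limit of the assay, > 32500 nM. Compound 2 `O=C(Nc1cccc(-n2cc(-c3ccncc3)c(-c3ccc(Cl)c(O)c3)n2)c1)Nc1ccc(Cl)c(Cl)c1` likewise stops at the limit, > 32500 nM. Among the measured compounds shown here, the single measured step, a step that the two limits leave unreadable from compound 1 to compound 2, is accordingly unreadable, and the set offers nothing firmer than the limit of > 32500 nM in this assay, at which 2 of the 3 values shown sit, as a reference point. Compound 4 `O=C(Nc1cccc(-n2cc(-c3ccncc3)c(-c3ccc(Cl)c(O)c3)n2)c1)Nc1ccc(Cl)c(C(F)(F)F)c1` differs from compound 3 by hydrogen in place of methyl on an oxygen on an aromatic ring. For the measured compounds named here, compounds 1 and 2 carry the same hydroxy group as compound 4 and both sit at the limit, while the number for compound 3 stands close to that same limit, so no step of readable size can be drawn from them for this change. The step of a 1.2-fold higher number from compound 3 to compound 4 (0.07 log units; within the scatter) is expected to be small, within the scatter, with no clear direction. Compound 4 is estimated at 35000 nM, between 15000 nM and 80000 nM, with a limit rather than a number the more likely outcome.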

Compound 4, concentration for total growth inhibition: 4160 nM
Beside the measured number, compound 4's estimate is 8.4-fold (0.92 log units) above it; the whole stated range lies above it.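

Hydrogen in place of methyl on an oxygen on an aromatic ring gives, in this assay, a 7.2-fold lower number from compound 3 to compound 4 (0.86 log units; beyond the scatter), the first readable step at this position. The hydroxy group alone does not set the reading: with it in place, trifluoromethyl in place of chloro on an aromatic carbon gives an at least 7.8-fold lower number from compound 2 to compound 4 (0.89 log units; beyond the scatter), and chloro in place of hydrogen on an aromatic carbon gives an at least 7.8-fold lower number from compound 1 to compound 4 (0.89 log units; beyond the scatter). Of the three compounds carrying the hydroxy group, only compound 4 gives a number rather than a limit, so these steps are the first to reach down from that reference point: the limit of > 32500 nM in this assay, at which 2 of the 4 values shown sit.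

On these data alone, whether the methoxy to hydroxy step keeps its size with the other substituent patterns of compounds 1 and 2 stays open. So does how an amine or a carboxylic acid would read on this position.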